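The compounds below may be only part of what the source reports. "The series", "measured", "known", "first", "only" and "open" are said of these compounds alone.

Measured in a functional assay on BT-20 cells (Homo sapiens) for cytotoxicity, read by MTT assay, with a stated time of 68 h; on this read-out lower numbers stand for stronger inhibition and higher numbers for weaker inhibition:
- compound 1 `O=C(/C=C/c1cccc(OCc2ccccc2)c1)c1ccc([N+](=O)[O-])cc1`: 80900 nM
- compound 2 `O=C(/C=C/c1cccc(OCc2ccccc2)c1)c1ccc(O)cc1`: 5100 nM

Of these two, compound 2 holds the lower number, at 5100 nM. Compound 3 `O=C(/C=C/c1cccc(OCc2ccccc2)c1)c1ccccc1Br` is the next to be measured, and it carries 2-bromophenyl in place of 4-hydroxyphenyl on a carbonyl carbon. Going by the values given here, only one measured step bears on this change, and only in part. That step, a 16-fold lower number from compound 1 to compound 2 (1.20 log units; beyond the scatter), put hydroxy in place of nitro on an aromatic carbon and was large. Among the compounds with values here, compound 3 also has no hydroxy, and no measured compound carries 2-bromophenyl, so the comparison is loose. A rise of moderate size is therefore expected, smaller than the measured step. The expected step is a 2.9-fold higher number from compound 2 to compound 3 (0.47 log units; beyond the scatter). In this assay, compound 3 is estimated at 15000 nM, with an expected range from 4000 nM to 60000 nM.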

Compound 3, half-maximal inhibitory concentration: 1800 nM
Estimate against measurement, compound 3: 8.3-fold (0.92 log units) above, outside the stated range (below it).
By their numbers in this assay, from the lowest: compound 3; then compound 2; then compound 1.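

In this assay, 2-bromophenyl on the carbonyl carbon brings a 2.8-fold lower number from compound 2 to compound 3 (0.45 log units; beyond the scatter), and it also brings a 45-fold lower number from compound 1 to compound 3 (1.65 log units; beyond the scatter). The lowest of the three numbers thus belongs to a group with 0 hydrogen-bond donors and 0 hydrogen-bond acceptors, so among these compounds a hydroxy group is not required at this place for a low number, although the earlier pair had pointed only to 4-hydroxyphenyl. No measurement offered here explains this order.

The compounds shown do not separate the effect of bromine itself from that of its location on the ring, since 2-bromophenyl differs from 4-hydroxyphenyl and 4-nitrophenyl in both respects. From the compounds shown here alone, it also remains open whether 2-chlorophenyl, or a phenyl ring carrying an amine or a carboxylic acid, would continue or break this order.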